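Chloro on the anilino ring of the urea-pyrimidine series

This account rests on a few compounds, and the source may have more. Where it says the series, first, only, none or still open, it means among the compounds named here.

Measured so far:
- compound 1 `O=C(Nc1ccc(Cl)cc1)Nc1nc(Sc2c[nH]c3ccccc23)cc(N2CCCC2)n1`: 10400 nM
- compound 2 `O=C(Nc1ccccc1)Nc1nc(Sc2c[nH]c3ccccc23)cc(N2CCCC2)n1`: 14900 nM
- compound 3 `O=C(Nc1ccccc1)Nc1nc(Nc2ccccc2)cc(Sc2c[nH]c3ccccc23)n1`: 26400 nM

All three were tested in a functional assay on PC-3 cells (Homo sapiens) for inhibition, with a stated time of 72 h; on this read-out lower numbers stand for stronger inhibition and higher numbers for weaker inhibition. Compound 2 differs from compound 1 by one change, (chloro in place of hydrogen on an aromatic carbon), which gave a 1.4-fold lower number from compound 2 to compound 1 (0.16 log units; within the scatter). Compound 3 differs from compound 2 in its core, (anilino in place of pyrrolidin-1-yl on an aromatic carbon), and that gave a 1.8-fold higher number from compound 2 to compound 3 (0.25 log units; within the scatter).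

Compound 4 `O=C(Nc1ccccc1)Nc1nc(Nc2ccc(Cl)cc2)cc(Sc2c[nH]c3ccccc23)n1` has not yet been measured. It differs from compound 3 by chloro in place of hydrogen on an aromatic carbon. Going by the values given here, this is the same change as the one from compound 2 to compound 1, made on a different core, and the two "place" descriptions read the same. Among the compounds with values here, since the earlier step was small, the expectation for compound 4 is a similarly small step, a 1.3-fold lower number from compound 3 to compound 4 (0.12 log units; within the scatter), resting on a 1.4-fold lower number from compound 2 to compound 1 (0.16 log units; within the scatter) as the only example of this change. The estimated value for compound 4 in this assay is 20000 nM, with a likely span from 8000 nM to 50000 nM.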

Compound 4, half-maximal inhibitory concentration: 32300 nM
Estimate against measurement, compound 4: 1.6-fold (0.21 log units) below; measured number inside the range.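

In this assay, putting chloro on the anilino ring gave a 1.2-fold higher number from compound 3 to compound 4 (0.09 log units; within the scatter), a step too small to tell apart from repeat scatter, and the same change on the other core behaved alike: the same change on two cores in this assay, a 1.4-fold lower number (0.16 log units; within the scatter) from compound 2 to compound 1 and a 1.2-fold higher number (0.09 log units; within the scatter) from compound 3 to compound 4, 1.8-fold (0.24 log units) apart, within the scatter of two such steps. This shows only that chloro carried over between these two cores without a step that can be read; with a single pair on each core, it does not show that chloro is without effect elsewhere in the series, and the two steps pointing opposite ways is no real reversal. Going by these compounds alone, the one step here beyond the scatter, a 2.2-fold higher number from compound 2 to compound 4 (0.34 log units; beyond the scatter), is modest and replaces pyrrolidin-1-yl with (4-chlorophenyl)amino, so it cannot separate the effect of the chloro from that of the anilino swap.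

The compounds shown leave open whether a methoxy group or a carboxylic acid on that same ring carbon would give a clearer step. They also leave open whether chloro would behave the same with a morpholine in place of the pyrrolidin-1-yl group.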